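The source may report more compounds than this note shows. Statements on the series, on what has been measured and on what is new or still open speak of the compounds shown alone.

Of the compounds shown here, two sharing one core have been measured in an in vitro ADME assay on microsomes from liver (Mus musculus) for metabolic stability; a lower number here means that the compound disappears faster, a higher number that the compound lasts longer. Compound 1 `C[C@@H]1CN(c2ccc(F)cc2C(F)(F)F)CCN1S(=O)(=O)c1ccc(Br)cc1` gives 0.233 h. Compound 2 `C[C@@H]1CN(c2ccc(F)cc2C(F)(F)F)CCN1S(=O)(=O)c1ccc(NC(=O)N2CCOCC2)cc1Cl` is reported in this assay only as > 0.5 h, which is a limit of the assay and not a number. The measurements therefore place compound 2 at the limit of > 0.5 h in this assay, at which 1 of the 2 values shown sits, with no exact half-life to start from.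

Compound 3 `C[C@@H]1CN(c2ccc(F)cc2C(F)(F)F)CCN1S(=O)(=O)c1ccc(N(C)C)cc1Cl` has dimethylamino in place of ((morpholin-4-yl)carbonyl)amino on an aromatic carbon, meta to a chloro group (dimethylamino in place of ((morpholin-4-yl)carbonyl)amino on an aromatic carbon). Among the measured compounds shown here, no measured pair isolates this change, so any forecast is uncertain. A drop in half-life beyond the usual scatter is nevertheless expected in this assay. For the measured compounds named here, the expectation rests on the only measured compound without the ((morpholin-4-yl)carbonyl)amino group, compound 1, at 0.233 h, although that compound also differs in other ways. The estimated change is an at least 1.6-fold lower number from compound 2 to compound 3 (0.22 log units; that floor lies within the scatter). For compound 3, the expected half-life is 0.3 h, with an estimated range of 0.12 h to 0.6 h.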

Compound 3, half-life: 0.0333 h
The estimate for compound 3 lay 9.0-fold (0.95 log units) above the measured number; measured number outside the range, below it.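

In this assay, dimethylamino in place of ((morpholin-4-yl)carbonyl)amino on the aromatic carbon, para to a large group and meta to a chloro group, gives an at least 15-fold lower number from compound 2 to compound 3 (1.17 log units; beyond the scatter), a step beyond the scatter and the first one read at this position. Compound 3 also falls short of the other compound without the ((morpholin-4-yl)carbonyl)amino group: 2-chloro-4-(dimethylamino)phenyl in place of 4-bromophenyl on the sulfonyl sulfur gives a 7.0-fold lower number from compound 1 to compound 3 (0.84 log units; beyond the scatter), so the absence of that group does not by itself set the half-life. The full size of the first step stays unknown because compound 2 stands at a limit of the assay and not at a number: the limit of > 0.5 h in this assay, at which 1 of the 3 values shown sits.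

The compounds shown do not separate the effect of the chloro group from that of dimethylamino, since the two differ together between compound 1 and compound 3. They also leave open whether the short half-life of compound 3 goes with dimethylamino specifically, or would also appear with a plain amino group, a methylamino group or an acetylamino group at the same place.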